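This account rests on a few compounds, and the source may have more. Where it says the series, first, only, none or still open, it means among the compounds named here.

Measured compounds:
compound 1, `O=C(CSC(=S)N[C@H]1CCOC1=O)Nc1ccc(Br)cc1`, 67400 nM in a functional assay on EC9706 cells (Homo sapiens) for cytotoxicity, read by MTT assay, with a stated time of 72 h; a higher number here means a weaker inhibitor, a lower number a stronger inhibitor
compound 2, `O=C(CSC(=S)N[C@H]1CCOC1=O)Nc1ccccc1`, > 128000 nM in this assay
compound 3, `O=C(CSC(=S)N[C@H]1CCOC1=O)Nc1ccc(C(=O)/C=C/c2ccccc2)cc1`, 44900 nM in this assay

Of the compounds shown here, three sharing one core have been tested. Compound 1 gives 67400 nM in this assay. For compound 2 the result is a limit of the assay, > 128000 nM, and not a number (the limit of > 128000 nM in this assay, at which 1 of the 3 values shown sits). Compound 3 gives 44900 nM.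

The change from compound 2 to compound 1 is bromo in place of hydrogen on an aromatic carbon. It produced an at least 1.8-fold lower number from compound 2 to compound 1 (0.27 log units; that floor lies within the scatter). The core of compound 3 differs from that of compound 2 by (2-phenylethenyl)carbonyl in place of hydrogen on an aromatic carbon, a change that brought an at least 2.8-fold lower number from compound 2 to compound 3 (0.45 log units; beyond the scatter). Compound 1 and compound 3 differ by a 1.5-fold lower number from compound 1 to compound 3 (0.18 log units; within the scatter).

Compound 4, `O=C(CSC(=S)N[C@H]1CCOC1=O)Nc1ccc(C(=O)/C=C/c2ccc(Br)cc2)cc1`, has not yet been measured. It differs from compound 3 by bromo in place of hydrogen on an aromatic carbon. The place of this change is worded the same as for the change from compound 2 to compound 1, so it is the same change, applied now to the 2-phenylethenyl arm of compound 3 rather than to the ring bearing the amide nitrogen.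

Because the earlier instance of this change gave an at least 1.8-fold lower number from compound 2 to compound 1 (0.27 log units; that floor lies within the scatter), a floor that lies within the scatter, a small lowering of the number is expected from compound 3 to compound 4, of about a 1.5-fold lower number from compound 3 to compound 4 (0.18 log units; within the scatter). Compound 4 is thus estimated at 30000 nM in this assay, with a likely range from 12000 nM to 75000 nM.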

Compound 4, half-maximal inhibitory concentration: 91200 nM
Estimate against measurement, compound 4: 3.0-fold (0.48 log units) below, outside the stated range (above it).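

In this assay, bromo in place of hydrogen on an aromatic carbon gave a 2.0-fold higher number from compound 3 to compound 4 (0.31 log units; beyond the scatter), and the effect of this change did not carry over from one core to the other: the same change on two cores in this assay, an at least 1.8-fold lower number (0.27 log units; that floor lies within the scatter) from compound 2 to compound 1 and a 2.0-fold higher number (0.31 log units; beyond the scatter) from compound 3 to compound 4, at least 3.8-fold (0.58 log units) apart, beyond the scatter of two such steps. The earlier step gives only a floor, and that floor lies within the scatter, as compound 2 sits at a limit of the assay and not at a number: the limit of > 128000 nM in this assay, at which 1 of the 4 values shown sits. The two instances therefore show that the outcome of this change differed between these two cores, but they do not establish a firm reversal of direction, they give no reason for the difference, and they offer no rule for other cores, since the bromo also sits on a different ring in each case, on the 2-phenylethenyl arm in compound 4 and on the ring bearing the amide nitrogen in compound 1.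

The compounds shown leave open whether chloro or methoxy in place of bromo on the 2-phenylethenyl arm would follow compound 4 or compound 3. They also leave open how a carboxylic acid or an amine at that place would read in this assay.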